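From hydroxy to methoxy: expected cytotoxicity of compound 4

The source may hold more compounds than are shown below. What is called first, only, known or untested is meant among the compounds shown, and "the series" means these compounds.

Compound 1 `COC(=O)c1c(-c2ccc([N+](=O)[O-])cc2)oc2cc(OC)ccc2c1=O` and compound 2 `COc1ccc2c(=O)c(C(=O)O)c(-c3ccc([N+](=O)[O-])cc3)oc2c1` share a core and differ by methyl in place of hydrogen on an oxygen next to a carbonyl group. In a functional assay on MCF7 cells (Homo sapiens) for cytotoxicity, read by MTT assay, with a stated time of 6 days (on this read-out lower numbers stand for an effect already at smaller amounts and higher numbers for an effect only at larger amounts of compound), compound 1 reaches only the limit > 25 ug/mL. Compound 2 likewise gives only the limit > 25 ug/mL. The step that the two limits leave unreadable from compound 2 to compound 1 therefore cannot be sized. Compound 3 `COc1cc(-c2cc(=O)c3cc(O)ccc3o2)cc(OC)c1OC` has a different core; how it differs from compound 2 is not broken down here. In this assay, among the compounds with values here, compound 3 also gives only the limit > 25 ug/mL, so that the limit of > 25 ug/mL in this assay, at which 3 of the 3 values shown sit, covers every value so far. Compound 4 `COc1ccc2oc(-c3cc(OC)c(OC)c(OC)c3)cc(=O)c2c1` is not yet measured; it differs from compound 3 by methyl in place of hydrogen on an oxygen on an aromatic ring, the same kind of change as from compound 2 to compound 1, though there the place was an oxygen next to a carbonyl group and here it is an oxygen on an aromatic ring. Because compound 3 reaches only the limit > 25 ug/mL, the step that the limit leaves unreadable from compound 3 to compound 4 is expected to be small. Compound 4 is estimated at 30 ug/mL.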

Compound 4, concentration for half-maximal effect: > 25 ug/mL
Compound 4 was reported as a limit; the forecaster's own chance of this, stated with the estimate: 80%; the middle value does not contradict the limit.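

Within the data shown here, compound 3 and compound 4 are each reported only as a limit, so no step between them can be sized: the limit of > 25 ug/mL in this assay, at which 4 of the 4 values shown sit.

The compounds shown leave open whether swapping hydroxy for methoxy changes cytotoxicity at all in this assay.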